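The source may hold more compounds than are shown below. What is called first, only, known or untested is meant among the compounds shown, and "the series" means these compounds.

Of the compounds shown here, three that share one core have been measured in a functional assay on BXPC-3 cells (Homo sapiens) for antiproliferative activity, read by sulforhodamine B assay, with a stated time of 72 h; a higher number here means a weaker inhibitor, a lower number a stronger inhibitor. With phenyl on the carbonyl carbon, compound 1 (`CC(C)(C)c1[nH]cnc1/C=c1\[nH]c(=O)/c(=C/c2cccc(C(=O)c3ccccc3)c2)[nH]c1=O`) gives 0.63 nM in this test. With pyrrolidin-1-yl at that place, compound 2 (`CC(C)(C)c1[nH]cnc1/C=c1\[nH]c(=O)/c(=C/c2cccc(C(=O)N3CCCC3)c2)[nH]c1=O`) gives 325 nM in the same test. With thiophen-3-yl, compound 3 (`CC(C)(C)c1[nH]cnc1/C=c1\[nH]c(=O)/c(=C/c2cccc(C(=O)c3ccsc3)c2)[nH]c1=O`) gives 1.56 nM and so holds the middle of the three numbers, far closer to compound 1 than to compound 2.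

The next compound is compound 4 (`CC(C)(C)c1[nH]cnc1/C=c1\[nH]c(=O)/c(=C/c2cccc(C(=O)c3ccco3)c2)[nH]c1=O`), and the change is furan-2-yl in place of thiophen-3-yl on a carbonyl carbon with furan-2-yl in place of thiophen-3-yl on a carbonyl carbon. Among the measured compounds shown here, the nearest precedent is the exchange of one aromatic ring for another, which gave a 2.5-fold higher number from compound 1 to compound 3 (0.39 log units; beyond the scatter) and was modest. The large steps, a 520-fold higher number from compound 1 to compound 2 (2.71 log units; beyond the scatter) and a 210-fold lower number from compound 2 to compound 3 (2.32 log units; beyond the scatter), both involve pyrrolidin-1-yl, and compound 4 has no such group, so they bear on it only weakly. For the measured compounds named here, only three compounds are available, and none of them carries a furan-2-yl group. A small step is therefore expected, with a slight lean towards a higher number. The expected size is a 1.6-fold higher number from compound 3 to compound 4 (0.20 log units; within the scatter) in this estimate. Compound 4 is estimated at 2.5 nM in this assay and is expected to fall from 0.8 nM to 8 nM when measured.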

Compound 4, half-maximal inhibitory concentration: 9.23 nM
Compound 4: the middle estimate sits 3.7-fold (0.57 log units) below what was measured, outside the stated range (above it).
By their numbers in this assay, from the lowest: compound 1; then compound 3; then compound 4; then compound 2.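

In this assay, replacing one five-membered aromatic ring with one hetero atom by another, with the same count of heavy atoms, gave a 5.9-fold higher number from compound 3 to compound 4 (0.77 log units; beyond the scatter) and was therefore not a neutral exchange at this place on the carbonyl carbon. The comparison with phenyl shows a larger loss, a 15-fold higher number from compound 1 to compound 4 (1.17 log units; beyond the scatter) in a large step, yet the comparison with pyrrolidin-1-yl gives a 35-fold lower number from compound 2 to compound 4 (1.55 log units; beyond the scatter), so furan-2-yl falls between the other aromatic rings and pyrrolidin-1-yl, and all three aromatic rings give lower numbers than pyrrolidin-1-yl does. No measurement is available that accounts for the gap between the furan-2-yl and thiophen-3-yl compounds.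

The step from compound 3 to compound 4 changes both the hetero atom and the point of attachment on the ring, and the compounds shown cannot separate the two; furan-3-yl and thiophen-2-yl would pull them apart. From the compounds shown here alone, it also remains open whether a six-membered ring carrying nitrogen, such as pyridin-3-yl, would stay close to phenyl or move towards the higher numbers seen here.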